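The source may hold more compounds than are shown below. What is called first, only, known or untested is meant among the compounds shown, and "the series" means these compounds.

Compound 1 `COc1cccc(-c2cc(-c3cc4cc(OC)ccc4[nH]3)no2)c1`, compound 2 `Cn1c(-c2cc(-c3ccc(F)cc3)no2)cc2ccccc21` and compound 3 `COc1ccc2[nH]c(-c3cc(-c4cccc(F)c4)on3)cc2c1` were examined in a functional assay on Calu-3 cells (Homo sapiens) for cytotoxicity, read by WST assay, with a stated time of 72 h; on this read-out higher numbers stand for weaker inhibition and lower numbers for stronger inhibition. In this assay compound 1 gives > 100000 nM, which is a limit of the assay and not a number. Compound 2 likewise gives only a limit, > 100000 nM. Compound 3 too sits at a limit, > 100000 nM. The change from compound 3 to compound 1 is methoxy in place of fluoro on an aromatic carbon, and its step that the two limits leave unreadable from compound 3 to compound 1 cannot be read because of the limit of > 100000 nM in this assay, at which 3 of the 3 values shown sit. The difference between the cores of compound 2 and compound 3 is not broken down here. Compound 4 `COc1ccc(-c2cc(-c3cc4ccccc4n3C)on2)cc1` arises from compound 2 by the same kind of change, (methoxy in place of fluoro on an aromatic carbon), the group now para to a large group rather than meta to a large group. In this assay the expected step is a step that the limit leaves unreadable from compound 2 to compound 4, which rests on the measured step that the two limits leave unreadable from compound 3 to compound 1 sitting at the limit of > 100000 nM in this assay, at which 3 of the 3 values shown sit. Compound 4 is estimated at 200000 nM, between 50000 nM and 1000000 nM.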

Compound 4, half-maximal inhibitory concentration: > 100000 nM
Compound 4 ended at the assay's limit; the forecaster's own chance of this, stated with the estimate: 85%; the middle value is on the limit's open side.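

No step can be read from compound 2 to compound 4, since both sit at a limit of the assay: (the limit of > 100000 nM in this assay, at which 4 of the 4 values shown sit). The compounds shown leave open in this assay how methoxy and fluoro actually compare.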